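Trifluoromethyl for dimethyl on the acetylated anilide

A few compounds are considered here, and "the series" means these few. Any claim that something is new, unique, unknown or untested is made for them only; others in the source may bear on it.

Compound 3 `CC(=O)Nc1cccc2c(-c3cccc(NC(=O)c4ccc(C)c(C)c4)c3)ccnc12` carries an acetyl on the aromatic amine of the shared core and a 3,4-dimethylphenyl on the carbonyl carbon of the anilide. In a functional assay on A375P cells (Homo sapiens) for antiproliferative activity, read by MTT assay, with a stated time of 48 h (a higher number here means a weaker inhibitor, a lower number a stronger inhibitor), compound 3 gives > 20000 nM, which is a limit of the assay and not a number. Compound 3 therefore sits only at the bounded end of the values shown, at the limit of > 20000 nM in this assay, at which 2 of the 3 values shown sit.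

The change to compound 4 `CC(=O)Nc1cccc2c(-c3cccc(NC(=O)c4cccc(C(F)(F)F)c4)c3)ccnc12` is 3-(trifluoromethyl)phenyl in place of 3,4-dimethylphenyl on a carbonyl carbon. The same exchange has been measured once, on the unacetylated pair. Compound 1 `Cc1ccc(C(=O)Nc2cccc(-c3ccnc4c(N)cccc34)c2)cc1C` gives > 20000 nM in this assay, a limit. Compound 2 `Nc1cccc2c(-c3cccc(NC(=O)c4cccc(C(F)(F)F)c4)c3)ccnc12` gives 7900 nM in this assay. That pair shows an at least 2.5-fold lower number from compound 1 to compound 2 (0.40 log units; beyond the scatter). The acetyl step itself, a step that the two limits leave unreadable from compound 1 to compound 3, runs between two limits and its size is not readable, so whether the acetylated core responds like the unacetylated one is open.

For compound 4 a downward move of roughly the size seen in the unacetylated pair is expected, that is an at least 1.6-fold lower number from compound 3 to compound 4 (0.22 log units; that floor lies within the scatter), with the caveat that the starting point of compound 3 is a limit. The estimate for compound 4 is 12000 nM, with a range from 4000 nM to 40000 nM, and a real chance that the assay again returns only a limit.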

Compound 4, half-maximal inhibitory concentration: 8000 nM
The estimate for compound 4 lay 1.5-fold (0.18 log units) above the measured number, within the range that was stated.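

The exchange of 3,4-dimethylphenyl for 3-(trifluoromethyl)phenyl on a carbonyl carbon now reads on the acetylated core as well in this assay, with an at least 2.5-fold lower number from compound 3 to compound 4 (0.39 log units; beyond the scatter), and it points the same way on both cores: the same change on two cores in this assay, an at least 2.5-fold lower number (0.40 log units; beyond the scatter) from compound 1 to compound 2 and an at least 2.5-fold lower number (0.39 log units; beyond the scatter) from compound 3 to compound 4; the limit leaves it open whether they differ

The acetyl step, which could not be read between the two limits of the dimethyl pair, can now be read on the trifluoromethyl pair, as a 1.0-fold higher number from compound 2 to compound 4 (0.01 log units; within the scatter), so at this level of activity the acetyl and the free amine on the shared core are not told apart. Compound 1 and compound 3, which both carry 3,4-dimethylphenyl, rest on a limit of the assay and not on a number, so the trifluoromethyl step stays a floor on either core: the limit of > 20000 nM in this assay, at which 2 of the 4 values shown sit.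

From the compounds shown here alone, whether the level pairing of the free amine and the acetyl holds for other groups on the carbonyl carbon stays open, since only the trifluoromethyl pair gives two numbers. Also open, going by these compounds, is whether a longer acyl chain such as butanoyl on the aromatic nitrogen, or a nitrile or morpholine on the phenyl of the anilide, would move the values in this assay further from the limit.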